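Chain extension on a carbamate-linked core

The source may hold more compounds than are shown below. What is called first, only, known or untested is meant among the compounds shown, and "the series" means these compounds.

Compound 1 `CCCCCCCCCCCCC(C)OC(=O)NC(=O)Nc1c(C(C)C)cccc1C(C)C` and compound 2 `CCCCCCCCCCCCCCC(C)OC(=O)NC(=O)Nc1c(C(C)C)cccc1C(C)C` share one core; compound 3 `CCCCCCCCCCCCC(C)OC(=O)NC(=O)Oc1c(C(C)C)cccc1C(C)C` and the unmeasured compound 4 `CCCCCCCCCCCCCCC(C)OC(=O)NC(=O)Oc1c(C(C)C)cccc1C(C)C` share another. The difference between the two cores is not broken down here.

In an assay on microsomes from intestine for inhibition of acyl-CoA:cholesterol acyltransferase (Oryctolagus cuniculus) (on this read-out higher numbers stand for weaker inhibition and lower numbers for stronger inhibition), compound 1 gives 46 nM. Compound 2 gives 6800 nM in this assay. The change between the two is ethyl in place of hydrogen on a saturated chain carbon, ten or more bonds along the chain from an oxygen next to a carbonyl group, and it gave a 150-fold higher number from compound 1 to compound 2 (2.17 log units; beyond the scatter). Compound 3 gives 17 nM in this assay; its number lies below that of compound 1 by a margin beyond the scatter, and far below that of compound 2.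

Compound 4 differs from compound 3 by ethyl in place of hydrogen on a saturated chain carbon, ten or more bonds along the chain from an oxygen next to a carbonyl group, the same change as from compound 1 to compound 2, at the same place on the chain. No second instance of this change exists among the measured compounds, and the only one available sits on a different core, so the expectation rests entirely on a 150-fold higher number from compound 1 to compound 2 (2.17 log units; beyond the scatter) carried over to the core of compound 3.

Compound 4 is expected to give 2000 nM in this assay. The expected step is a 120-fold higher number from compound 3 to compound 4 (2.07 log units; beyond the scatter). Among the measured compounds shown here, for compound 4 the expected range runs from 300 nM to 12000 nM, set wide because a 150-fold higher number from compound 1 to compound 2 (2.17 log units; beyond the scatter) is the single measured instance of this change and the cores differ.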

Compound 4, half-maximal inhibitory concentration: 58 nM
Beside the measured number, compound 4's estimate is 34-fold (1.54 log units) above it; the measured number lies below the stated range.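

Ethyl in place of hydrogen on this saturated chain carbon moves the number the same way on the second core, with a 3.4-fold higher number from compound 3 to compound 4 (0.53 log units; beyond the scatter). In this assay the direction of the change carries over between the two cores but its size does not: the same change on two cores in this assay, a 150-fold higher number (2.17 log units; beyond the scatter) from compound 1 to compound 2 and a 3.4-fold higher number (0.53 log units; beyond the scatter) from compound 3 to compound 4, 43-fold (1.64 log units) apart, beyond the scatter of two such steps

With a single pair on each core, this shows that in this series a step measured on one core is no safe guide to the size of the same step on the other, while it does not show which part of the difference between the cores goes with the gap, or whether either step is typical of its core.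

Still open, going by these compounds, is how the number moves with chain length on each core, and whether a longer chain, or a shorter one such as a decyl chain, would show the steep rise of the first core as an abrupt edge or as part of a gradual trend. Also open, on these data alone, is whether a chain carrying an amine or a carboxylic acid would show the same gap between the two cores.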